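Returning a Piperidinyl Group at the Saturated Ring Carbon

This account rests on a few compounds, and the source may have more. Where it says the series, first, only, none or still open, it means among the compounds named here.

compound 1 `COc1cc(C)c(S(=O)(=O)N(C)CCOCC(=O)N2CCC(C3CCN(C)CC3)CC2)c(C)c1`: 9
compound 2 `COc1cc(C)c(S(=O)(=O)N(C)CCOCC(=O)N2CCC(C(O)CN(C)C)CC2)c(C)c1`: 7.4

For the measured compounds named here, in a functional assay on Umbilical vein for antagonist activity at B1 bradykinin receptor (Homo sapiens), using Schild analysis, with a stated time of 30 min (a higher number here means a more potent compound, by a factor of ten per unit of this negative logarithm, a lower number a less potent compound), compound 2 gives 7.4, the lowest of the two numbers; its nearest neighbour is compound 1, and the one measured step, a number 1.60 log units lower from compound 1 to compound 2 (beyond the scatter), is large. Compound 3 `COc1cc(C)c(S(=O)(=O)N(C)CCOCC(=O)N2CCC(C3CCN(C(C)C)CC3)CC2)c(C)c1` differs from compound 2 by 1-isopropylpiperidin-4-yl in place of 2-(dimethylamino)-1-hydroxyethyl on a saturated ring carbon, which reverses the kind of change seen in that step. Compound 3 is therefore expected to regain most of what compound 2 lost, an estimated step of a number 1.40 log units higher from compound 2 to compound 3 (beyond the scatter). For compound 3 the expected value in this assay is 8.8, within a range from 8.2 to 9.4.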

Compound 3, negative logarithm of the antagonist equilibrium constant: 9.3
Compound 3: middle estimate off by 0.50 log units, on the low side, within the range that was stated.
By their numbers in this assay, from the lowest: compound 2; then compounds 1 and 3 (each within the scatter of the next).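

In this assay, 1-isopropylpiperidin-4-yl in place of 2-(dimethylamino)-1-hydroxyethyl gives a number 1.90 log units higher from compound 2 to compound 3 (beyond the scatter) on this saturated ring carbon, so the large drop seen with the open-chain group does not persist once a substituted piperidine returns. Isopropyl in place of methyl on the ring amine nitrogen gives a number 0.30 log units higher from compound 1 to compound 3 (within the scatter) and leaves compound 1 and compound 3 indistinguishable here. No measurement shown gives a reason for either step.

Going by these compounds, whether a cyclohexyl group or a plain hydrogen on that ring nitrogen would keep this level stays open. Also open, on these data alone, is whether the hydroxyl or the open chain of compound 2 goes with its lower number.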